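The source may hold more compounds than are shown below. What is called first, only, known or untested is meant among the compounds shown, and "the series" means these compounds.

In a functional assay on MCF7 cells (Homo sapiens) for antiproliferative activity, read by MTT assay, with a stated time of 72 h (on this read-out higher numbers stand for weaker inhibition and lower numbers for stronger inhibition), compound 1 `CC1=CC[C@H]2[C@H](CC[C@]2(C)O)C(C)(C)[C@@H]1CC[C@H]1[C@]2(C)CC[C@H](OC(=O)c3ccncc3)C(C)(C)O[C@H]2CC[C@@]1(C)O` gives 25300 nM and compound 2 `CC1=CC[C@H]2[C@H](CC[C@]2(C)O)C(C)(C)[C@@H]1CC[C@H]1[C@]2(C)CC[C@H](OC(=O)c3ccc(Cl)cc3)C(C)(C)O[C@H]2CC[C@@]1(C)O` gives 24100 nM, so compound 2 stands level with compound 1, within the scatter. Compound 3 `CC1=CC[C@H]2[C@H](CC[C@]2(C)O)C(C)(C)[C@@H]1CC[C@H]1[C@]2(C)CC[C@H](OCc3ccccc3)C(C)(C)O[C@H]2CC[C@@]1(C)O` differs from compound 2 by benzyl in place of (4-chlorophenyl)carbonyl on an oxygen on a saturated carbon. Within the data shown here, the only measured step, a 1.0-fold lower number from compound 1 to compound 2 (0.02 log units; within the scatter), is small, but it keeps the carbonyl, so it offers weak guidance on this change. With nothing pointing either way, the step of a 1.2-fold lower number from compound 2 to compound 3 (0.08 log units; within the scatter) in this assay is expected to stay within the scatter. For compound 3 the estimated value is 20000 nM, with an expected range of 8000 nM to 45000 nM.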

Compound 3, half-maximal inhibitory concentration: > 50000 nM
Compound 3 ended at the assay's limit (the forecaster's own chance of this, stated with the estimate: 10%); middle value at least 2.5-fold (0.39 log units) away from the limit.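

Compound 3 gives > 50000 nM in this assay, which is a limit of the assay and not a number. Among these compounds, the aryl group on the carbonyl made no visible difference earlier, but benzyl on this oxygen gives an at least 2.0-fold higher number from compound 2 to compound 3 (0.31 log units; beyond the scatter), the first step here beyond the scatter. Against the pyridinyl analogue the reading is weaker, an at least 1.9-fold higher number from compound 1 to compound 3 (0.29 log units; that floor lies within the scatter), so only the comparison with compound 2 clearly separates the pair. Benzyl differs from (4-chlorophenyl)carbonyl in both the carbonyl and the chlorine, so the compounds shown do not separate the two. A 4-chlorobenzyl group or a free hydroxyl on this oxygen would leave that open question answerable.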